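A few compounds are considered here, and "the series" means these few. Any claim that something is new, unique, unknown or untested is made for them only; others in the source may bear on it.

The measured compounds:
compound 1, `Cc1cc(S(=O)(=O)/N=C(\N)n2nccc2-c2ccccc2)c(SCc2ccc(C(F)(F)F)cc2)cc1Cl`, giving 19000 nM in an ADME assay on HaCaT cells (Homo sapiens) for cytotoxicity, read by MTT assay, with a stated time of 72 h; on this read-out lower numbers stand for stronger inhibition and higher numbers for weaker inhibition;
compound 2, `Cc1cc(S(=O)(=O)/N=C(\N)n2nccc2-c2ccccc2)c(SCc2cccc(Cl)c2)cc1Cl`, giving 10000 nM;
compound 3, `Cc1cc(S(=O)(=O)/N=C(\N)n2nccc2-c2ccccc2)c(SCc2cccc(C(F)(F)F)c2)cc1Cl`, giving 18000 nM.

Among these three numbers compound 3 stands second highest, yet the step of a 1.1-fold lower number from compound 1 to compound 3 (0.02 log units; within the scatter) and the step of a 1.8-fold higher number from compound 2 to compound 3 (0.26 log units; within the scatter) both lie within the scatter, so none of the three is separated from the others. Compound 4, `Cc1cc(S(=O)(=O)/N=C(\N)n2nccc2-c2ccccc2)c(SCc2ccccc2C(F)(F)F)cc1Cl`, has not yet been measured in this assay. The change is 2-(trifluoromethyl)phenyl in place of 3-(trifluoromethyl)phenyl on a saturated chain carbon bound to a sulfur. The earlier change of the same kind, a 1.1-fold lower number from compound 1 to compound 3 (0.02 log units; within the scatter), was small, and the other two steps, a 1.9-fold lower number from compound 1 to compound 2 (0.28 log units; within the scatter) and a 1.8-fold higher number from compound 2 to compound 3 (0.26 log units; within the scatter), were likewise small. Compound 4 is therefore expected to show no step beyond the scatter, a 1.2-fold lower number from compound 3 to compound 4 (0.08 log units; within the scatter). The estimated value of compound 4 is 15000 nM, with a range of 7000 nM to 35000 nM.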

Compound 4, half-maximal inhibitory concentration: 20000 nM
Compound 4: the middle estimate sits 1.3-fold (0.12 log units) below what was measured; low and high end bracket the measured number.
By their numbers in this assay, from the lowest: compounds 2, 3, 1 and 4 (each within the scatter of the next).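

In this assay the step to 2-(trifluoromethyl)phenyl on a saturated chain carbon bound to a sulfur, a 1.1-fold higher number from compound 3 to compound 4 (0.05 log units; within the scatter), stays within the scatter, and a 1.1-fold higher number from compound 1 to compound 4 (0.02 log units; within the scatter) does too, so the three trifluoromethyl-bearing compounds cannot be told apart. Even a 2.0-fold higher number from compound 2 to compound 4 (0.30 log units; within the scatter) lies within the scatter, so compound 4 is not separated from the 3-chlorophenyl compound either. No supporting evidence bears on this result. Going by these compounds, what remains open is whether an amine or a carboxylic acid on this phenyl ring would give a step beyond the scatter. A longer chain between the sulfur and the ring is equally untested here.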